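Two bromophenyl isoxazoles at the assay ceiling, a methoxy variant

The source may report more compounds than this note shows. Statements on the series, on what has been measured and on what is new or still open speak of the compounds shown alone.

Compound 1 `O=[N+]([O-])c1ccc(CN2CCC(n3cc(CC(OCc4cc(-c5ccc(Br)cc5)no4)c4ccc(Br)cc4)nn3)CC2)cc1` — > 25000 nM
Compound 2 `O=[N+]([O-])c1ccc(CN2CCC(n3cc(CC(OCc4cc(-c5ccc(F)cc5)no4)c4ccc(Br)cc4)nn3)CC2)cc1` — > 25000 nM

In a functional assay on HCT-116 cells (Homo sapiens) for cytotoxicity, with a stated time of 48 h (a higher number here means a weaker inhibitor, a lower number a stronger inhibitor), compound 1 gives > 25000 nM, which is a limit of the assay rather than a number. In this assay compound 2 likewise gives > 25000 nM, again a limit rather than a number. The step that the two limits leave unreadable from compound 1 to compound 2 therefore cannot be sized, since the limit of > 25000 nM in this assay, at which 2 of the 2 values shown sit, describes where both values sit. Compound 3 `COc1cccc(-c2cc(COC(Cc3cn(C4CCN(Cc5ccc([N+](=O)[O-])cc5)CC4)nn3)c3ccc(Br)cc3)on2)c1` carries 3-methoxyphenyl in place of 4-fluorophenyl on an aromatic carbon. For the measured compounds named here, no measured step bears on a methoxyphenyl group, and the one step available gives no readable size, so no direction can be drawn from it. Compound 3 is expected to stay at the ceiling, with an estimate of 30000 nM and a range from 10000 nM to 100000 nM. The step that the limit leaves unreadable from compound 2 to compound 3 is accordingly expected to remain unreadable.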

Compound 3, half-maximal inhibitory concentration: > 25000 nM
Compound 3: a limit, no number (the forecaster's own chance of this, stated with the estimate: 80%); the middle value is on the limit's open side.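

Compound 3, like compound 1 and compound 2, sits at a limit of the assay rather than at a number, so the steps among them cannot be read: the limit of > 25000 nM in this assay, at which 3 of the 3 values shown sit. Left open is whether these three compounds differ in strength at all, and whether any group on this aromatic carbon would give a readable value.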